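The compounds below may be only part of what the source reports. "The series", "measured", "known", "first", "only" and "open" are said of these compounds alone.

Compound 1 `COc1cc(N(CC2CC2)c2cccc(C(F)(F)F)c2)cnc1C(=O)[C@H]1C[C@@H]1C(=O)O` is the starting point. In an assay for inhibition of leukotriene C4 synthase (Homo sapiens), read by LC-MS, with stated times of 15 min and 30 min (on this read-out lower numbers stand for stronger inhibition and higher numbers for weaker inhibition), compound 1 gives 6.42 nM. Compound 2 `COc1cc(N(CC2CC2)c2cc(C(F)(F)F)ccc2F)cnc1C(=O)[C@H]1C[C@@H]1C(=O)O` differs by fluoro in place of hydrogen on an aromatic carbon, and in this assay compound 2 gives 2.08 nM, a step of a 3.1-fold lower number from compound 1 to compound 2 (0.49 log units; beyond the scatter). Compound 3 `COc1cc(N(CC2CC2)c2ccc(F)c(Cl)c2)cnc1C(=O)[C@H]1C[C@@H]1C(=O)O` carries a different core, the difference being (3-chloro-4-fluorophenyl in place of 3-(trifluoromethyl)phenyl on a nitrogen on an aromatic ring); in this assay compound 3 gives 5.26 nM, which is a 1.2-fold lower number from compound 1 to compound 3 (0.09 log units; within the scatter). Compound 4 `COc1cc(N(CC2CC2)c2cc(Cl)c(F)cc2F)cnc1C(=O)[C@H]1C[C@@H]1C(=O)O` is not yet measured. It differs from compound 3 by fluoro in place of hydrogen on an aromatic carbon. Among the compounds with values here, this is the same kind of change as the one from compound 1 to compound 2, but not the same: here the new fluoro sits meta to a fluoro group and para to a chloro group, whereas before it sat para to a trifluoromethyl group. Resting on a 3.1-fold lower number from compound 1 to compound 2 (0.49 log units; beyond the scatter), a step of a 2.4-fold lower number from compound 3 to compound 4 (0.38 log units; beyond the scatter) is expected, although the different surroundings make it less certain. Compound 4 is therefore estimated at 2.2 nM, with a likely range from 0.9 nM to 5.5 nM.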

Compound 4, half-maximal inhibitory concentration in the leukotriene C4 synthase assay: 1.97 nM
Beside the measured number, compound 4's estimate is 1.1-fold (0.05 log units) above it; measured number inside the range.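

In the leukotriene C4 synthase assay compound 4 gives 1.97 nM; adding the fluoro gives a 2.7-fold lower number from compound 3 to compound 4 (0.43 log units; beyond the scatter), while the full exchange of the aromatic group on the nitrogen gives a 3.3-fold lower number from compound 1 to compound 4 (0.51 log units; beyond the scatter). The same single-atom change therefore kept much the same size on the two cores: the same change on two cores in the leukotriene C4 synthase assay, a 3.1-fold lower number (0.49 log units; beyond the scatter) from compound 1 to compound 2 and a 2.7-fold lower number (0.43 log units; beyond the scatter) from compound 3 to compound 4, 1.2-fold (0.06 log units) apart, within the scatter of two such steps. Within the data shown here, this is only two matched pairs, so it supports carrying the change between these two cores, but it sets no general rule for the series and does not explain why the number falls. In a physicochemical assay for lipophilicity, read by LC-MS, in phosphate buffer, measured as octanol-water partition, at pH 7.4 (a lower number here means a more polar compound, a higher number a more lipophilic compound), compound 3 gives 1.2 and compound 4 gives 1.1. In the physicochemical assay adding the fluoro gives a number 0.10 log units lower from compound 3 to compound 4 (within the scatter).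

From the compounds shown here alone, it remains open whether the step would hold on a core carrying a nitrile instead of the chloro. Also open, going by these compounds, is whether a chloro or a methoxy group in place of the new fluoro would give a step of similar size.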